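Chloro for fluoro on the anilino ring of the series

This account rests on a few compounds, and the source may have more. Where it says the series, first, only, none or still open, it means among the compounds named here.

Compound 1 `O=C(CSc1nc(Nc2ccccc2)c2ccccc2n1)Nc1cccc(F)c1`, compound 2 `O=C(CSc1nc(Nc2ccccc2)c2ccccc2n1)Nc1cccc(Cl)c1` and compound 3 `C=CC(=O)Nc1cccc(NC(=O)CSc2nc(Nc3ccc(F)cc3)c3ccccc3n2)c1` have been measured in a functional assay on MDA-MB-231 cells (Homo sapiens) for inhibition, read by MTT assay, with a stated time of 72 h; on this read-out lower numbers stand for stronger inhibition and higher numbers for weaker inhibition; compound 4 `C=CC(=O)Nc1cccc(NC(=O)CSc2nc(Nc3ccc(Cl)cc3)c3ccccc3n2)c1` has not. In this assay compound 1 reaches only > 50000 nM, which is a limit of the assay (the limit of > 50000 nM in this assay, at which 1 of the 3 values shown sits). In this assay compound 2 gives 16500 nM, and compound 3 gives 9490 nM. The change chloro in place of fluoro on an aromatic carbon yields an at least 3.0-fold lower number from compound 1 to compound 2 (0.48 log units; beyond the scatter). The difference between the cores of compound 3 and compound 1 is not broken down here. Compound 4 carries the same kind of change, (chloro in place of fluoro on an aromatic carbon), though the place differs: in compound 2 the chloro sits meta to a large group, in compound 4 para to a large group. Compound 4 is expected to show a 2.4-fold lower number from compound 3 to compound 4 (0.38 log units; beyond the scatter). This expectation rests on an at least 3.0-fold lower number from compound 1 to compound 2 (0.48 log units; beyond the scatter), a step that is itself bounded by a limit. Compound 4 is estimated at 4000 nM, between 1500 nM and 12000 nM.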

Compound 4, half-maximal inhibitory concentration: 10300 nM
Beside the measured number, compound 4's estimate is 2.6-fold (0.41 log units) below it; measured number inside the range.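

In this assay the change from 4-fluorophenyl to 4-chlorophenyl gives a 1.1-fold higher number from compound 3 to compound 4 (0.04 log units; within the scatter), and set beside the earlier step, it does not carry over in size from one core to the other: the same change on two cores in this assay, an at least 3.0-fold lower number (0.48 log units; beyond the scatter) from compound 1 to compound 2 and a 1.1-fold higher number (0.04 log units; within the scatter) from compound 3 to compound 4, at least 3.2-fold (0.51 log units) apart, beyond the scatter of two such steps. Compound 1 gives > 50000 nM, which is a limit of the assay. The chloro also sits in a different place in each pair, so these steps do not show whether the core or the place accounts for the gap.

Still open, as far as these compounds go, is how the same change behaves at one shared place on both cores. Also open, from the compounds shown here alone, is how a methoxy or nitrile group would compare with the chloro of the 4-chlorophenyl group in compound 4.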